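Shortening a Butyl Chain to Propyl

This account rests on a few compounds, and the source may have more. Where it says the series, first, only, none or still open, it means among the compounds named here.

In a functional assay on HCT-116 cells (Homo sapiens) for cytotoxicity, read by MTT assay, with a stated time of 72 h (on this read-out lower numbers stand for stronger inhibition and higher numbers for weaker inhibition), compound 1 (`Oc1ccc(C2C/C(=N\NC(=S)N3CCOCC3)c3ccc(O)cc3O2)cc1`), which carries morpholin-4-yl on a thiocarbonyl carbon, gives 63500 nM as its number. Compound 2 (`Oc1ccc(C2C/C(=N\NC(=S)N3CCCC3)c3ccc(O)cc3O2)cc1`) has pyrrolidin-1-yl in that place and gives 52300 nM as its number. Compound 3 (`CCCCNC(=S)N/N=C1\CC(c2ccc(O)cc2)Oc2cc(O)ccc21`) has butylamino in that place and gives 49300 nM as its number, which stands within the scatter of both others, so the three cannot be ranked.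

Compound 4 (`CCCNC(=S)N/N=C1\CC(c2ccc(O)cc2)Oc2cc(O)ccc21`) comes from compound 3 through hydrogen in place of methyl on a saturated chain carbon, three bonds along the chain from an amide-type nitrogen with hydrogen in place of methyl on a saturated chain carbon, three bonds along the chain from an amide-type nitrogen, so that butyl becomes propyl. Within the data shown here, no measured step shortens a chain. The nearest evidence is the exchange of whole groups on the thiocarbonyl carbon, seen in a 1.2-fold lower number from compound 1 to compound 2 (0.08 log units; within the scatter) and a 1.3-fold lower number from compound 1 to compound 3 (0.11 log units; within the scatter) and a 1.1-fold lower number from compound 2 to compound 3 (0.03 log units; within the scatter), and all three stay within the scatter. These exchanges alter more of the molecule than the removal of one methyl does, so no step beyond the scatter is expected in this assay and no direction can be argued. The expected size is a 1.1-fold higher number from compound 3 to compound 4 (0.02 log units; within the scatter) and nothing more. The estimate for compound 4 is 52000 nM with an expected range from 30000 nM to 85000 nM.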

Compound 4, half-maximal inhibitory concentration: 54000 nM
For compound 4 the middle estimate is 1.0-fold (0.02 log units) below the measured one; measured number inside the range.
By their numbers in this assay, from the lowest: compounds 3, 2, 4 and 1 (each within the scatter of the next).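

In this assay, among these compounds, the step from butyl to propyl gives a 1.1-fold higher number from compound 3 to compound 4 (0.04 log units; within the scatter), the first evidence on shortening the chain itself, and this change on a saturated chain carbon, three bonds along the chain from an amide-type nitrogen, stays within the scatter. The propylamino group of compound 4 also shows no separation from either ring-bearing group, with a 1.0-fold higher number from compound 2 to compound 4 (0.01 log units; within the scatter) and a 1.2-fold lower number from compound 1 to compound 4 (0.07 log units; within the scatter) both printed as within the scatter, so these four groups on the thiocarbonyl carbon give no ranking in this cell assay. No supporting measurement is available to explain why these exchanges leave the values so close together.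

The compounds shown leave open whether the flat picture extends to a much longer chain such as octyl, or to a benzyl group or a chain ending in a carboxylic acid or an amine, any of which might produce a step beyond the scatter. They also leave open whether changes to the shared core, rather than to this end of the molecule, would move the number more.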